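The compounds below may be only part of what the source reports. "The series", "measured", "known", "first", "only" and "open" are said of these compounds alone.

Among the compounds with values here, compound 1 `CN1CCN(CCCCCCn2c3c(c4ccccc42)C(=O)c2c[n+]([O-])c4ccccc4c2C3=O)CC1` gives 330 nM in a functional assay on A549 cells (Homo sapiens) for cytotoxicity, read by MTT assay, with a stated time of 72 h (a lower number here means a stronger inhibitor, a higher number a weaker inhibitor), the highest of the three numbers measured so far, although all three lie within the scatter of one another: compound 2 `CN(C)CCCCn1c2c(c3ccccc31)C(=O)c1c[n+]([O-])c3ccccc3c1C2=O` gives 310 nM in this assay, and compound 3 `O=C1c2c[n+]([O-])c3ccccc3c2C(=O)c2c1c1ccccc1n2CCCCn1ccnc1` gives 170 nM. Compound 4 `O=C1c2c[n+]([O-])c3ccccc3c2C(=O)c2c1c1ccccc1n2CCN1CCCCC1` differs from compound 1 (piperidin-1-yl in place of 4-(4-methylpiperazin-1-yl)butyl on a saturated chain carbon, two bonds along the chain from an aromatic nitrogen). The measured steps that bear on this are the exchanges of the group carried on the chain at the aromatic nitrogen: a 1.1-fold lower number from compound 1 to compound 2 (0.03 log units; within the scatter) and a 1.9-fold lower number from compound 1 to compound 3 (0.29 log units; within the scatter), with a 1.8-fold lower number from compound 2 to compound 3 (0.26 log units; within the scatter) between those two. None of them moves beyond the scatter, so the step expected in this assay is a 1.1-fold lower number from compound 1 to compound 4 (0.04 log units; within the scatter), nothing beyond the scatter. Compound 4 is therefore estimated at 300 nM, with a range from 120 nM to 750 nM.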

Compound 4, half-maximal inhibitory concentration: 1080 nM
For compound 4 the middle estimate is 3.6-fold (0.56 log units) below the measured one; measured number above the stated range.
By their numbers in this assay, from the lowest: compounds 3, 2 and 1 (each within the scatter of the next); then compound 4.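

In this assay, within the data shown here, the group on the chain at the aromatic nitrogen now matters: with piperidin-1-yl on a saturated chain carbon, two bonds along the chain from an aromatic nitrogen, there is a 3.3-fold higher number from compound 1 to compound 4 (0.51 log units; beyond the scatter), a 3.5-fold higher number from compound 2 to compound 4 (0.54 log units; beyond the scatter) and a 6.4-fold higher number from compound 3 to compound 4 (0.80 log units; beyond the scatter), all beyond the scatter, as no earlier step was. The end group and the chain length change together in these steps, so the two cannot be told apart, and nothing measured here accounts for the rise. The compounds leave open whether piperidin-1-yl on a longer chain keeps this higher number, and whether a morpholine on the same short chain behaves alike.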